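This account rests on a few compounds, and the source may have more. Where it says the series, first, only, none or still open, it means among the compounds named here.

Compound 1, `O=C1NC(O)(CCn2cc(C3=CCCCC3)nn2)C(OCc2ccccc2)=C1OCc1ccccc1`: 67200 nM
Compound 2, `COC1=C(OC)C(O)(CCn2cc(-c3ccc(C(C)(C)C)cc3)nn2)NC1=O`: 30400 nM

Of the compounds shown here, two have so far been measured in a functional assay on PC-3 cells (Homo sapiens) for antiproliferative activity, read by MTT assay, with a stated time of 24 h; a higher number here means a weaker inhibitor, a lower number a stronger inhibitor. Compound 1 gives 67200 nM in this assay, while compound 2 gives 30400 nM, the lower of the two numbers. The gap between them lies beyond the scatter of repeated measurements, so compound 2 stands as the stronger inhibitor of the pair. The two compounds differ in more than one place, however, so nothing about any single change can be read from that comparison.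

The next compound, compound 3, is `COC1=C(OC)C(O)(CCn2cc(-c3ccccc3)nn2)NC1=O`. It differs from compound 2 in one place: hydrogen in place of tert-butyl on an aromatic carbon. Going by the values given here, no measured pair shows what this particular change does in this assay, so the size of the step can only be expected, not derived. The expected step is a 1.5-fold higher number from compound 2 to compound 3 (0.17 log units; within the scatter), a modest weakening that could still fall within the scatter. Compound 3 is estimated at 45000 nM in this assay, with a range from 15000 nM to 130000 nM.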

Compound 3, half-maximal inhibitory concentration: 35300 nM
Compound 3: the middle estimate sits 1.3-fold (0.11 log units) above what was measured; low and high end bracket the measured number.
By their numbers in this assay, from the lowest: compounds 2, 3 and 1 (each within the scatter of the next, the first and the last beyond it).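

Hydrogen in place of tert-butyl on an aromatic carbon, para to a large group, gives a 1.2-fold higher number from compound 2 to compound 3 (0.06 log units; within the scatter) in this assay, and this is the first single change in the series that can be read on its own. The earlier comparison of compound 1 and compound 2 could not speak to this position, whereas this pair shows that a group of four carbons and a bare hydrogen at this place on the six-membered aromatic ring cannot be told apart in this read-out. Nothing measured here explains this outcome, and no supporting data bear on it.

Only tert-butyl and hydrogen are shown at this position, so it remains open whether an amine, a carboxylic acid or a longer chain there would shift the number beyond the scatter, or whether the position tolerates such groups as it does these two. On these data alone, it is also open what a single change elsewhere on the shared core would do, such as a benzyloxy group in place of one methoxy group.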